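From Ethoxy to Diethylamino on Compound 3

The compounds below may be only part of what the source reports. "The series", "measured", "known", "first", "only" and "open" are said of these compounds alone.

In a functional assay on T-24 cells (Homo sapiens) for cytotoxicity, read by colorimetric assay and MTT assay (a lower number here means a stronger inhibitor, a higher number a weaker inhibitor), three compounds have been measured so far. Compound 1 (`COc1cccc2cc(-c3ccccc3)c(O)nc12`) gives 10000 nM here, compound 2 (`COc1cc(OC)c2cc(-c3ccccc3)c(O)nc2c1`) gives 10000 nM as well, and compound 3 (`CCOC(=O)Cn1c(=O)c(-c2ccc(OC)cc2)cc2c(OC)cc(OC)cc21`) gives 10000 nM too, so compound 3 stands level with the other two. Compound 4 (`CCN(CC)C(=O)Cn1c(=O)c(-c2ccc(OC)cc2)cc2c(OC)cc(OC)cc21`) differs from compound 3 in one place: diethylamino in place of ethoxy on a carbonyl carbon. For the measured compounds named here, no measured pair shows what such a swap does, so the only guide is compound 3 at 10000 nM and its level neighbours. The expected change is a 1.3-fold lower number from compound 3 to compound 4 (0.10 log units; within the scatter) and would stay within the usual scatter in this assay for this pair. Compound 4 is estimated at 8000 nM with a likely range from 2500 nM to 12000 nM overall.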

Compound 4, half-maximal inhibitory concentration: 10000 nM
For compound 4 the middle estimate is 1.3-fold (0.10 log units) below the measured one; the range from low to high includes it.
By their numbers in this assay, from the lowest: compounds 1, 2, 3 and 4 (each within the scatter of the next).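

Diethylamino in place of ethoxy on a carbonyl carbon gives no change at the digits printed from compound 3 to compound 4 (within the scatter) in this assay and so offers the first direct reading of a change at this place. Going from ethoxycarbonyl to diethylcarbamoyl, with a larger group entering by heavy-atom count, leaves the printed number as it stood. Nothing given here explains this result.

Still open, as far as these compounds go, is whether a carboxylic acid or a longer chain on this carbonyl carbon would move the number beyond the scatter. It is also unclear whether changes elsewhere on the shared core would do so.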